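Lengthening the Amide Alkene on a Cyano Analogue

The source may report more compounds than this note shows. Statements on the series, on what has been measured and on what is new or still open speak of the compounds shown alone.

Measured so far in an ADME assay on L02 cells (Homo sapiens) for inhibition, read by MTT assay, with a stated time of 72 h; a lower number here means a stronger inhibitor, a higher number a weaker inhibitor: compound 1 `COc1ccc(Nc2nc(Oc3cccc(NC(=O)C=C(C)C)c3)c3sccc3n2)cc1` gives 48900 nM; compound 2 `C=CC(=O)Nc1cccc(Oc2nc(Nc3cccc(OC)c3)nc3ccsc23)c1` gives 30300 nM. Compound 3 `C=CC(=O)Nc1cccc(Oc2nc(Nc3cccc(C#N)c3)nc3ccsc23)c1` gives only a limit, > 50000 nM, in this assay (the limit of > 50000 nM in this assay, at which 1 of the 3 values shown sits). Going by the values given here, the one single-point step measured, an at least 1.6-fold higher number from compound 2 to compound 3 (0.21 log units; that floor lies within the scatter), has a floor that lies within the scatter, so compound 3 stands at the weak end without a fixed number.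

Compound 4 `CC(C)/C=C/C(=O)Nc1cccc(Oc2nc(Nc3cccc(C#N)c3)nc3ccsc23)c1` differs from compound 3 by 3-methylbut-1-en-1-yl in place of vinyl on a carbonyl carbon. Among the compounds with values here, no measured step changes this amide alkene alone; compound 1 carries a longer alkene together with a differently placed methoxy group, and its value and that of compound 2 sit close together. Compound 4 is therefore expected near 55000 nM, between 25000 nM and 120000 nM, quite possibly reported again only as a limit. The step that the limit leaves unreadable from compound 3 to compound 4 is expected to stay within the scatter.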

Compound 4, half-maximal inhibitory concentration: > 50000 nM
Compound 4: a limit, no number (the forecaster's own chance of this, stated with the estimate: 60%); the middle value is on the limit's open side.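

Compound 3 and compound 4 both give only a limit, so no step can be read between them: the limit of > 50000 nM in this assay, at which 2 of the 4 values shown sit.

From the compounds shown here alone, what stays open in this assay is where either compound truly lies, and whether 3-methylbut-1-en-1-yl in place of vinyl on the carbonyl carbon changes the number at all.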